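This account rests on a few compounds, and the source may have more. Where it says the series, first, only, none or still open, it means among the compounds named here.

Measured in an ADME assay on Vero cells (Chlorocebus sabaeus) for cytotoxicity, read by CellTiter-Glo, with a stated time of 72 h; a higher number here means that more compound is tolerated, a lower number that less compound is tolerated:
- compound 1 `[O-][n+]1nc(NC2CCC2)[n+]([O-])c2ccccc21` gives 8.9 ug/mL
- compound 2 `CCNc1n[n+]([O-])c2cc(F)ccc2[n+]1[O-]` gives 4.6 ug/mL
- compound 3 `[O-][n+]1nc(NC2CC2)[n+]([O-])c2ccc(F)cc21` gives 1.3 ug/mL

Compound 3 has the lowest number of the three, and its gaps to compound 1 and compound 2 lie beyond the scatter. Compound 4 `[O-][n+]1nc(NC2CCC2)[n+]([O-])c2ccc(F)cc21` differs from it in one place: cyclobutyl in place of cyclopropyl on a nitrogen on an aromatic ring. Cyclobutyl stands in place of cyclopropyl on a nitrogen on an aromatic ring.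

Within the data shown here, one measured step bears on this group: a 3.5-fold lower number from compound 2 to compound 3 (0.55 log units; beyond the scatter), which brought in the cyclopropyl. Compound 1, which carries cyclobutylamino on a core without fluorine, gives 8.9 ug/mL. A modest rise in this assay is therefore expected, on thin evidence. The expected change is a 2.3-fold higher number from compound 3 to compound 4 (0.36 log units; beyond the scatter). The estimate for compound 4 is 3 ug/mL, within a range of 1.2 ug/mL to 8 ug/mL.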

Compound 4, half-maximal cytotoxic concentration: 1.6 ug/mL
Estimate against measurement, compound 4: 1.9-fold (0.27 log units) above, within the range that was stated.
By their numbers in this assay, from the lowest: compounds 3 and 4 (each within the scatter of the next); then compounds 2 and 1 (each within the scatter of the next).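

In this assay, enlarging the ring on the nitrogen from cyclopropyl to cyclobutyl makes no clear difference on the fluorine-bearing core: a 1.2-fold higher number from compound 3 to compound 4 (0.09 log units; within the scatter) is a step within the scatter. Other single changes do register, with a 2.9-fold lower number from compound 2 to compound 4 (0.46 log units; beyond the scatter) for ethyl replaced by cyclobutyl and a 5.6-fold lower number from compound 1 to compound 4 (0.75 log units; beyond the scatter) for fluoro replacing hydrogen, so the higher number of compound 1 does not carry over once fluoro is present. Nothing at hand gives a cause for these steps. Going by these compounds, it remains open whether a larger ring such as cyclopentyl on that nitrogen would stay level with compound 4. A cyclic amine such as morpholine in place of cyclobutylamino is equally untested among these compounds.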